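This account rests on a few compounds, and the source may have more. Where it says the series, first, only, none or still open, it means among the compounds named here.

Compound 1 `CC1(c2ccccc2)CC(=O)N(CC(=O)N2CCN(c3ccc(Cl)cc3)CC2)C1=O`: 300 mg/kg in a functional assay on the whole organism (strain CD-1) with Mus musculus as the target, with a stated time of 2 h; a higher number here means that more compound is needed for the effect, a lower number that less compound is needed
Compound 2 `COc1cccc(N2CCN(C(=O)CN3C(=O)CC(C)(c4ccccc4)C3=O)CC2)c1`: "not active" (no number reported) in this assay
Compound 3 `CC1(c2ccccc2)CC(=O)N(CC(=O)N2CCN(c3ncccn3)CC2)C1=O`: 100 mg/kg in this assay

Compound 3 stands lowest of the two numbers recorded; its nearest neighbour is compound 1, and the step from that compound to it is a 3.0-fold lower number from compound 1 to compound 3 (0.48 log units; beyond the scatter). Compound 2 gave no number, so it offers no scale.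

Compound 4 `CC1(c2ccccc2)CC(=O)N(CC(=O)N2CCN(c3cccc(Cl)c3Cl)CC2)C1=O` differs from compound 3 in one place: 2,3-dichlorophenyl in place of pyrimidin-2-yl on an amine nitrogen in a ring. Among the measured compounds shown here, only one measured step bears on this. From compound 1 to compound 3, a 3.0-fold lower number from compound 1 to compound 3 (0.48 log units; beyond the scatter) came from putting pyrimidin-2-yl in place of 4-chlorophenyl on the same ring nitrogen. Compound 4 reverses that direction, returning a chlorinated phenyl ring, now 2,3-dichlorophenyl, to that nitrogen, and compound 2, which also carries a substituted phenyl there, gave no number at all.

The expectation for compound 4 in this assay is therefore a higher number than compound 3, a step of about a 3.0-fold higher number from compound 3 to compound 4 (0.48 log units; beyond the scatter), with a real chance that no number is found. The estimate for compound 4 is 300 mg/kg, within a range of 100 mg/kg to 1000 mg/kg.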

Compound 4, minimum effective dose: "not active" (no number reported)
No number was reported for compound 4, and the estimate cannot be compared.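

Compound 4 gave no number in this assay, so no step from compound 3 to compound 4 can be read, and nothing shown accounts for this result. The compounds shown leave open how large the difference between pyrimidin-2-yl and 2,3-dichlorophenyl on this amine nitrogen is.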